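The source may hold more compounds than are shown below. What is called first, only, known or untested is meant among the compounds shown, and "the series" means these compounds.

The measured compounds, each in a functional assay on the whole organism (Tail, strain ICR) with Mus musculus as the target, in the tail flick test, with a stated time of 30 min, at a dose of 25 umol/kg by the oral route; on this read-out lower numbers stand for a weaker effect and higher numbers for a stronger effect at the one dose given:
compound 1 `O=C(O)[C@@H]1CCCN1C(=O)CN(c1nc(Cl)nc2[nH]cnc12)C1CC1`, giving 31.5%
compound 2 `CC(C)[C@H](NC(=O)CN(c1ncnc2c1ncn2C1CCCCO1)C1CC1)C(=O)OCc1ccccc1`, giving 21.8%
compound 3 `CC(C)C[C@H](NC(=O)CN(c1nc(Cl)nc2[nH]cnc12)C1CC1)C(=O)OCc1ccccc1`, giving 33.9%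

The three numbers lie within the usual scatter of one another, so none of the three compounds can be set apart on this read-out; compound 1 sits between the other two without being distinguishable from either. Compound 4 `O=C(CN(c1nc(Cl)nc2[nH]cnc12)C1CC1)N[C@@H](CO)C(=O)O` has not yet been measured. It differs from compound 1 in one place: (1-carboxy-2-hydroxyethyl)amino in place of 2-carboxypyrrolidin-1-yl on a carbonyl carbon. Within the data shown here, no measured pair differs in a single place, so no measured step shows how this kind of change plays out. Compound 4 is therefore expected to give about 30% in this assay, with a likely range from 15% to 45%. This estimate means an expected step of a number 1.5 percentage points lower from compound 1 to compound 4 (within the scatter), no larger than the scatter.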

Compound 4, a percentage reported as activity, at one dose (the size of the read-out at that dose, not a potency): 38.7%
The estimate for compound 4 lay 8.7 percentage points below the measured number; measured number inside the range.
By their numbers in this assay, from the lowest: compounds 2, 1, 3 and 4 (each within the scatter of the next, the first and the last beyond it).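

In this assay, among these compounds, this is the first comparison of two compounds that differ in one place: (1-carboxy-2-hydroxyethyl)amino replaces 2-carboxypyrrolidin-1-yl on a carbonyl carbon, a step of a number 7.2 percentage points higher from compound 1 to compound 4 (within the scatter). On this read-out, then, the ring can give way to an open chain without a shift beyond the scatter. Nothing measured explains the result.

The compounds shown leave open whether (1-carboxyethyl)amino, which lacks the hydroxy group, would read the same. They also leave open how a primary amide would fare in place of the carboxylic acid.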